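A few compounds are considered here, and "the series" means these few. Any claim that something is new, unique, unknown or untested is made for them only; others in the source may bear on it.

In a functional assay on HeLa cells (Homo sapiens) for inhibition, read by CCK-8 assay, with a stated time of 72 h (a higher number here means a weaker inhibitor, a lower number a stronger inhibitor), compound 1 `Cc1ccccc1NS(=O)(=O)c1cccc(CCCCCCNC(=O)/C=C/c2cccnc2)c1` gives 2.34 nM, while compound 2 `CCc1ccc(NS(=O)(=O)c2cccc(CCCCCCNC(=O)/C=C/c3cccnc3)c2)cc1` gives 132 nM, the higher number of the two and so the weaker inhibitor. Compound 3 `O=C(/C=C/c1cccnc1)NCCCCCCc1cccc(S(=O)(=O)Nc2ccc(Cl)cc2)c1` differs from compound 2 by chloro in place of ethyl on an aromatic carbon, para to a large group. Going by the values given here, the one measured step, a 56-fold higher number from compound 1 to compound 2 (1.75 log units; beyond the scatter), is large, but it replaced 2-methylphenyl with 4-ethylphenyl, so no measured step isolates this swap of ethyl for chloro. The expected change is therefore small, a 1.5-fold lower number from compound 2 to compound 3 (0.17 log units; within the scatter), with no shift beyond the scatter. For compound 3 the estimated value is 90 nM, with a range of 20 nM to 350 nM.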

Compound 3, half-maximal inhibitory concentration: 170 nM
The estimate for compound 3 lay 1.9-fold (0.28 log units) below the measured number; the range from low to high includes it.
By their numbers in this assay, from the lowest: compound 1; then compounds 2 and 3 (each within the scatter of the next).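

In this assay, swapping ethyl for chloro para to a large group gives a 1.3-fold higher number from compound 2 to compound 3 (0.11 log units; within the scatter) and so leaves the reading essentially unchanged. The wide gap to compound 1 also persists with 4-chlorophenyl, at a 73-fold higher number from compound 1 to compound 3 (1.86 log units; beyond the scatter) in all, so it is not peculiar to 4-ethylphenyl. No evidence is available to explain either result. Still open, on these data alone, is how an amine or a carboxylic acid would fare at this place. A 4-methylphenyl group would help show whether the gap follows the position of the substituent or its identity.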